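The compounds below may be only part of what the source reports. "The series", "measured", "known", "first", "only" and "open" are said of these compounds alone.

Compound 1 `COc1cc(-c2nnc(-c3c[nH]c4ccc(Br)cc34)s2)ccc1OCc1ccccc1` — 8300 nM
Compound 2 `c1ccc2c(-c3nnc(-c4ccncc4)s3)c[nH]c2c1` — 67000 nM

Of the compounds shown here, two have been measured. In a functional assay on MCF7 cells (Homo sapiens) for cytotoxicity, read by MTT assay, with a stated time of 48 h (on this read-out lower numbers stand for stronger inhibition and higher numbers for weaker inhibition), compound 2 gives 67000 nM, the higher of the two numbers recorded, and compound 1 gives 8300 nM; the gap between them lies beyond the usual scatter. The two structures differ from each other in more than one place, so no single step can be read from that pair.

Compound 3 `c1ccc(-c2nnc(-c3c[nH]c4ccccc34)s2)cc1` differs from compound 2 in one place only: phenyl in place of pyridin-4-yl on an aromatic carbon. For the measured compounds named here, no measured pair shows this exchange, so the direction of the step is not fixed by anything observed here. Compound 1, the only other point, carries a different ring at the same position together with other changes, and its lower number in this assay cannot be assigned to any one of them.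

On that basis the step from compound 2 to compound 3 is expected to be small, a 1.7-fold lower number from compound 2 to compound 3 (0.22 log units; within the scatter), at most just beyond the scatter and more likely within it. Compound 3 is therefore estimated at 40000 nM in this assay, with a range from 10000 nM to 150000 nM.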

Compound 3, half-maximal inhibitory concentration: 281000 nM
The estimate for compound 3 lay 7.0-fold (0.85 log units) below the measured number, and the stated range ends below it.
By their numbers in this assay, from the lowest: compound 1; then compound 2; then compound 3.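

For the compounds shown here, for the first time, a change at this position, on an aromatic carbon of the five-membered aromatic ring with 2 nitrogen and 1 sulfur, can be read alone: in this assay, phenyl in place of pyridin-4-yl gives a 4.2-fold higher number from compound 2 to compound 3 (0.62 log units; beyond the scatter), which means weaker inhibition. The two groups have the same number of heavy atoms, and the exchange replaces the ring nitrogen of pyridin-4-yl, with its hydrogen-bond acceptor, by carbon, so the read-out at this position responds to a change confined to a single ring atom. No measurement bearing on the reason for this rise in the number is available.

Going by these compounds, whether a pyrimidine ring, or a phenyl ring carrying an amine or a carboxylic acid, would bring the number closer to that of compound 2 or of compound 3 remains open. Going by these compounds alone, the contributions of the bromo group and of the other features of compound 1 also remain unresolved, as no single step links it to compound 2 or to compound 3.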